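Replacing the carboxy group of compound 3 with methyl

A few compounds are considered here, and "the series" means these few. Any claim that something is new, unique, unknown or untested is made for them only; others in the source may bear on it.

Compound 1 `C[C@H](O)Cc1cc(-c2ccnc3[nH]nc(C(F)(F)F)c23)cc(C2(C#N)CC2)c1` gives 37%
Compound 2 `COCC(O)Cc1cc(-c2ccnc3[nH]nc(C(F)(F)F)c23)cc(C2(C#N)CC2)c1` gives 51%
Compound 3 `N#CC1(c2cc(CC(=O)O)cc(-c3ccnc4[nH]nc(C(F)(F)F)c34)c2)CC1` gives 95%

These values come from an ADME assay on S9 fraction from liver (Rattus norvegicus) for metabolic stability, read by LC-MS, using NADPH, with a stated time of 60 min, tested at 10 uM (on this read-out higher numbers stand for a more stable compound and lower numbers for a less stable compound), and place compound 3 highest of the three, with its gaps to both others beyond the scatter. Compound 4 `CCc1cc(-c2ccnc3[nH]nc(C(F)(F)F)c23)cc(C2(C#N)CC2)c1` shares the core of compound 3 and differs from it in one place. The change, (methyl in place of carboxy on a saturated chain carbon bound to an aromatic carbon), puts methyl in place of carboxy on a saturated chain carbon bound to an aromatic carbon, so carboxymethyl becomes ethyl.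

For the measured compounds named here, two measured steps bear on this. Both are large and both end at the carboxy compound: a number 58 percentage points higher from compound 1 to compound 3 (beyond the scatter) and a number 44 percentage points higher from compound 2 to compound 3 (beyond the scatter). The step of a number 14 percentage points higher from compound 1 to compound 2 (beyond the scatter) is only modest, so the two chains without carboxy lie closer to each other. Compound 4 lacks carboxy too, which makes a number 58 percentage points higher from compound 1 to compound 3 (beyond the scatter) and a number 44 percentage points higher from compound 2 to compound 3 (beyond the scatter), read in reverse, the best available guide. Going by the values given here, no measured compound carries an ethyl chain, however, so this remains an extrapolation.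

A large fall is therefore expected in this assay for this change. The expected step is a number 62 percentage points lower from compound 3 to compound 4 (beyond the scatter) as an estimate. Compound 4 is estimated at 33%, with an expected range from 12% up to 55% on this measure.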

Compound 4, percent of the compound remaining: 78%
For compound 4 the middle estimate is 45 percentage points below the measured one, outside the stated range (above it).
By their numbers in this assay, from the lowest: compound 1; then compound 2; then compound 4; then compound 3.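

In this assay, the carboxy group turns out to be less decisive for a high number than compounds 1 and 2 alone suggested: the change costs only a modest step, a number 17 percentage points lower from compound 3 to compound 4 (beyond the scatter), though that step remains beyond the scatter. Losing the carboxy group therefore does not by itself bring a compound down to the level of the two with hydroxy-bearing groups, as the plain methyl group stands clearly above both, with a number 27 percentage points higher from compound 2 to compound 4 (beyond the scatter) and the larger a number 41 percentage points higher from compound 1 to compound 4 (beyond the scatter), so among these four compounds the lowest numbers go with 1-hydroxyethyl and 1-hydroxy-2-methoxyethyl. No measurement offered here explains this order of the four compounds.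

Going by these compounds, it remains open whether a longer chain, such as an added ethyl or propyl group in place of the methyl, would keep the number of compound 4 or lower it, and whether an amine at this place would behave like the carboxy group or like the hydroxy-bearing groups. A hydroxymethyl group in place of the carboxy would also be informative, since it would show whether a hydroxy group on a short chain gives a number closer to compound 1 or to compound 4.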